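This account rests on a few compounds, and the source may have more. Where it says the series, first, only, none or still open, it means among the compounds named here.

In a functional assay on ECa-109 cells for inhibition, with ECa-109 cell line (Homo sapiens) as the target, read by sulforhodamine B assay (on this read-out higher numbers stand for weaker inhibition and lower numbers for stronger inhibition), compound 2 `O=C1C(Nc2ccc(Br)cc2)=CC(=O)c2c1nc1n2[C@H]2OC[C@@H](O)[C@H]2OC1` gives 1980 nM, and compound 1 `O=C1C(Nc2ccccc2F)=CC(=O)c2c1nc1n2[C@H]2OC[C@@H](O)[C@H]2OC1` gives 2660 nM. These two numbers lie within the scatter of each other, so compound 2 stands level with compound 1. Compound 3 `O=C1C=C(NC2CCCCC2)C(=O)c2c1nc1n2[C@H]2OC[C@@H](O)[C@H]2OC1` has only a limit, > 16000 nM.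

Compound 4 `COc1ccccc1NC1=CC(=O)c2c(nc3n2[C@H]2OC[C@@H](O)[C@H]2OC3)C1=O` arises by 2-methoxyphenyl in place of 4-bromophenyl on an amine nitrogen, with 2-methoxyphenyl in place of 4-bromophenyl on an amine nitrogen. For the measured compounds named here, one measured step bears on this, a swap of phenyl groups at that nitrogen: a 1.3-fold lower number from compound 1 to compound 2 (0.13 log units; within the scatter). On that small step, no change beyond the scatter is expected and no direction can be assigned. The expected step is a 1.3-fold higher number from compound 2 to compound 4 (0.10 log units; within the scatter). Compound 4 is estimated at 2500 nM, with an expected range of 1000 nM to 6500 nM.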

Compound 4, half-maximal inhibitory concentration: > 4000 nM
Compound 4: a limit, no number; the forecaster's own chance of this, stated with the estimate: 8%; at least 1.6-fold (0.20 log units) between middle value and limit.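

Compound 4 gives no number at this nitrogen, only a limit: the limit of > 4000 nM in this assay, at which 1 of the 4 values shown sits.

The change can therefore be read only as floors: an at least 2.0-fold higher number from compound 2 to compound 4 (0.30 log units; that floor lies within the scatter), and an at least 1.5-fold higher number from compound 1 to compound 4 (0.17 log units; that floor lies within the scatter). Unlike the earlier swap of phenyl groups here, this one leaves room for a real loss, but neither floor establishes one, so (2-methoxyphenyl)amino is not separated from the other two arylamino groups.

Going by these compounds, how far the true value of compound 4 lies from that limit remains open. Also open, on these data alone, is how a phenyl carrying a nitrile or a dimethylamino group would read at this nitrogen.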